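The compounds below may be only part of what the source reports. "The series", "measured", "known", "first", "only" and "open" are said of these compounds alone.

Three compounds have been measured in a functional assay on the whole organism for antagonist activity, with Mus musculus as the target; a higher number here means that more compound is needed for the effect, a lower number that less compound is needed:
Compound 1 `COc1cc(N)c(Cl)cc1NC(=O)C1CCN(Cc2ccccc2)CC1` gives 0.5 mg/kg.
Compound 2 `COc1cc(N)c(Cl)cc1NC(=O)C1CCN(C/C=C/c2ccccc2)CC1` gives > 10 mg/kg, which is a limit of the assay rather than a number.
Compound 3 `COc1cc(N)c(Cl)cc1NC(=O)C1CCN(Cc2ccc(OCc3ccccc3)cc2)CC1` gives > 4 mg/kg, also a limit of the assay.

Compound 2 therefore stands at the limit of > 10 mg/kg in this assay, at which 1 of the 3 values shown sits; its exact number is not known, and it is one of two compounds here for which only a limit is available. The step of an at least 20-fold higher number from compound 1 to compound 2 (1.30 log units; beyond the scatter) shows that putting 2-phenylethenyl in place of phenyl on the saturated chain carbon bound to the amine nitrogen in the ring made a much less active compound, and an at least 8.0-fold higher number from compound 1 to compound 3 (0.90 log units; beyond the scatter) shows that benzyloxy in place of hydrogen on an aromatic carbon also raised the number. Both steps enlarge the compound and both weaken it.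

Compound 4 `CCCN1CCC(C(=O)Nc2cc(Cl)c(N)cc2OC)CC1` is not yet measured. Compared with compound 2, the change is ethyl in place of 2-phenylethenyl on a saturated chain carbon bound to an amine nitrogen in a ring. For the measured compounds named here, this removes the group that, in the step from compound 1 to compound 2, was associated with the loss of activity, but it also leaves no aromatic ring on that chain, which none of the measured compounds shows. The expected direction is toward a lower number, without a firm anchor. Compound 4 is expected to give about 2 mg/kg, between 0.5 mg/kg and 10 mg/kg, an estimated step of an at least 5.0-fold lower number from compound 2 to compound 4 (0.69 log units; beyond the scatter).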

Compound 4, dose for half-maximal effect: > 10 mg/kg
Compound 4: no number, only a limit (the forecaster's own chance of this, stated with the estimate: 30%); middle value at least 5.0-fold (0.69 log units) away from the limit.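

In this assay, the step of an at least 20-fold higher number from compound 1 to compound 4 (1.30 log units; beyond the scatter) shows that removing the aromatic ring from this position does not bring activity back: with ethyl in place of phenyl on the saturated chain carbon bound to the amine nitrogen in the ring, the compound is much less active than compound 1. Size alone therefore does not explain the earlier losses, since the small ethyl of compound 4 and the larger 2-phenylethenyl of compound 2 both fall well short of the phenyl of compound 1. The step from compound 2 to compound 4 cannot be read, since both compounds give only a limit of the assay and not a number: the limit of > 10 mg/kg in this assay, at which 2 of the 4 values shown sit.

On these data alone, only compound 1 gives an actual number, so how much activity compound 2, compound 3 and compound 4 retain is unknown. As far as these compounds go, it also remains open whether the ring at this position must be aromatic, which cyclohexyl in place of the phenyl of compound 1 could test, and whether 2-phenylethyl, a saturated chain carrying the same ring, would keep the activity.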